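The source may report more compounds than this note shows. Statements on the series, on what has been measured and on what is new or still open speak of the compounds shown alone.

Measured so far:
Compound 1 `CCOc1ccc(C2(c3ccc(O)cc3)C(=O)Nc3c2ccc(F)c3F)cc1` gives 11 nM in a functional assay on MCF7 cells (Homo sapiens) for cytotoxicity, read by WST assay, with a stated time of 72 h; a lower number here means a stronger inhibitor, a higher number a weaker inhibitor.
Compound 2 `O=C1Nc2c(ccc(F)c2F)C1(c1ccc(O)cc1)c1cccnc1` gives 63 nM in this assay.

Compound 2 stands at the higher of the two numbers; the step of a 5.7-fold higher number from compound 1 to compound 2 (0.76 log units; beyond the scatter) separates it from compound 1, which holds the lower. Compound 3 `O=C1Nc2c(ccc(F)c2F)C1(CC1CCCCC1)c1ccc(O)cc1` differs from compound 2 in one place: cyclohexylmethyl in place of pyridin-3-yl on a saturated ring carbon. Going by the values given here, no measured step covers a cyclohexylmethyl group, or any group without an aromatic ring, at this saturated ring carbon. Among the compounds with values here, the only step in hand, a 5.7-fold higher number from compound 1 to compound 2 (0.76 log units; beyond the scatter), shows that exchanging the group at this position moves this assay by a modest amount beyond the scatter. The exchange from pyridin-3-yl to cyclohexylmethyl is a wider structural change than that one, so a shift of similar or greater size is expected, direction uncertain, a weaker number judged somewhat more likely. Compound 3 is estimated at 150 nM, range 30 nM to 800 nM, which means an expected step of a 2.4-fold higher number from compound 2 to compound 3 (0.38 log units; beyond the scatter).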

Compound 3, half-maximal inhibitory concentration: 102 nM
Compound 3: the middle estimate sits 1.5-fold (0.17 log units) above what was measured; the range from low to high includes it.
By their numbers in this assay, from the lowest: compound 1; then compounds 2 and 3 (each within the scatter of the next).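

In this assay, cyclohexylmethyl in place of pyridin-3-yl on the saturated ring carbon gives a 1.6-fold higher number from compound 2 to compound 3 (0.21 log units; within the scatter), so in this pair a six-membered non-aromatic carbon ring on a methyl link and a six-membered aromatic ring with one hetero atom cannot be told apart. An aromatic ring and a hydrogen-bond acceptor in this group are therefore not required for a value in this range, at least in compound 2 and compound 3. 4-Ethoxyphenyl stands apart from cyclohexylmethyl, with a 9.3-fold higher number from compound 1 to compound 3 (0.97 log units; beyond the scatter) for that exchange, and nothing on hand accounts for either step.

From the compounds shown here alone, it remains open whether that gap depends on the ethoxy group or on the phenyl ring that carries it. Also unresolved is how an amine, a carboxylic acid or a longer alkyl chain would read at this ring carbon.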